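A few compounds are considered here, and "the series" means these few. Any claim that something is new, unique, unknown or untested is made for them only; others in the source may bear on it.

Compound 1 `CC(=O)N(C)c1ccc(Nc2nccc(-c3cccnc3)n2)cc1` is the starting point. In a functional assay for inhibition, with Homo sapiens as the target (on this read-out higher numbers stand for weaker inhibition and lower numbers for stronger inhibition), compound 1 gives 900 nM. Within the data shown here, its closest measured neighbour is compound 3 `CC(=O)N(C)c1ccc(Nc2nccc(-c3ccccn3)n2)cc1`, which in this assay gives 1800 nM; the only single-site step among the measured compounds, a 2.0-fold higher number from compound 1 to compound 3 (0.30 log units; within the scatter), arises from pyridin-2-yl in place of pyridin-3-yl on an aromatic carbon, and the two numbers sit within the scatter of each other. Compound 2 `COc1ccc(N(C)c2nccc(-c3ccncc3)n2)cc1` is reported in this assay only as a limit, > 24000 nM, as described by the limit of > 24000 nM in this assay, at which 1 of the 3 values shown sits; it differs from compound 1 at more than one place, so its limit cannot be traced to one change.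

The unmeasured compound 4 `Oc1ccc(Nc2nccc(-c3cccnc3)n2)cc1` differs from compound 1 by hydroxy in place of acetyl(methyl)amino on an aromatic carbon. Among the measured compounds shown here, no measured step touches this position: the one measured step concerns the pyridyl ring, not the group on the six-membered carbon ring, and compound 2 offers only a limit. The expectation therefore rests on the value of compound 1 alone, with wide uncertainty on either side. The estimate expects a 1.7-fold higher number from compound 1 to compound 4 (0.22 log units; within the scatter), a step not beyond the scatter in either direction. Compound 4 is accordingly expected to give 1500 nM, with a range from 300 nM to 8000 nM.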

Compound 4, half-maximal inhibitory concentration: 5100 nM
For compound 4 the middle estimate is 3.4-fold (0.53 log units) below the measured one; the measured number falls inside the stated range.
By their numbers in this assay, from the lowest: compounds 1 and 3 (each within the scatter of the next); then compound 4. At a limit, above all of these: compound 2.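

Hydroxy in place of acetyl(methyl)amino gives a 5.7-fold higher number from compound 1 to compound 4 (0.75 log units; beyond the scatter), the first single-site step among the compounds shown that lies beyond the scatter, so in this assay the number does respond to the group on the six-membered aromatic ring of carbon only. The step is modest, and compound 4 still gives a plain number, 5100 nM, rather than a limit, so acetyl(methyl)amino is not required at this position for a measured value in this read-out; the swap, however, changes the heavy-atom count, the double bond outside aromatic rings and the hydrogen-bond donor count all at once, and this single step cannot separate them. No property measured for these compounds bears on why the number rises with this change.

From the compounds shown here alone, whether an amine, a carboxylic acid or a longer chain ending in hydroxy at this position would give a number nearer that of compound 1 or that of compound 4 stays open. Also open, going by these compounds, is whether hydroxy would bring a step of similar size on compound 3, which carries pyridin-2-yl instead of pyridin-3-yl.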